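The source may report more compounds than this note shows. Statements on the series, on what has been measured and on what is new or still open speak of the compounds shown alone.

Compounds measured so far:
compound 1, `Clc1ccc(OCc2nc3c(OCCC4CCNCC4)cccc3n2CCCC2CCCNC2)cc1`, 7 nM
compound 2, `Clc1ccc(OCc2nc3ccccc3n2CCC2CCCCN2)cc1`, 7860 nM
compound 3, `Clc1ccc(OCc2nc3ccccc3n2CCCC2CCCCN2)cc1`, 3230 nM

All three were tested in an assay on isolated protein for binding affinity to Neuropeptide Y receptor type 1 (Homo sapiens); a lower number here means a stronger inhibitor, a higher number a weaker inhibitor. Within the data shown here, compound 3 stands second highest of the three numbers: its nearest neighbour is compound 2, and the only step within this set that involves compound 3 is a 2.4-fold lower number from compound 2 to compound 3 (0.39 log units; beyond the scatter). Compound 1, which carries a piperidin-3-yl on the same chain as well as a further substituent on the shared core, gives 7 nM. Compound 3 gives 3230 nM. The number for compound 1 is far lower than that for compound 3.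

The unmeasured compound 4, `Clc1ccc(OCc2nc3ccccc3n2CCCC2CCCNC2)cc1`, differs from compound 3 in one place: piperidin-3-yl in place of piperidin-2-yl on a saturated chain carbon, three bonds along the chain from an aromatic nitrogen. Among the measured compounds shown here, no measured pair isolates this change. The step from compound 2 to compound 3 alters the chain, not the ring attachment. The gap between compound 1 and compound 3 combines the ring change with an additional group on the core, so that gap does not isolate the present change either. Compound 4 is therefore expected to improve on compound 3 by a moderate step, a 4.0-fold lower number from compound 3 to compound 4 (0.61 log units; beyond the scatter), in this assay. Compound 4 is estimated at 800 nM, with a range from 150 nM to 3000 nM.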

Compound 4, inhibition constant: 700 nM
Compound 4: middle estimate off by 1.1-fold (0.06 log units), on the high side, and the stated range covers the measured number.
By their numbers in this assay, from the lowest: compound 1; then compound 4; then compound 3; then compound 2.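

In this assay, the change from 3-(piperidin-2-yl)propyl to 3-(piperidin-3-yl)propyl gives a 4.6-fold lower number from compound 3 to compound 4 (0.66 log units; beyond the scatter), so the attachment point on the piperidine ring is now seen on its own, with the chain held constant. The step of an 11-fold lower number from compound 2 to compound 4 (1.05 log units; beyond the scatter) combines this new ring attachment with the longer chain, and together these two changes take the number across a large step. Compound 4 also separates the group on the core from the ring attachment: the step of a 100-fold higher number from compound 1 to compound 4 (2.00 log units; beyond the scatter), with hydrogen in place of 2-(piperidin-4-yl)ethoxy on an aromatic carbon, shows that a large share of the low number of compound 1 goes with that group and not with the piperidin-3-yl alone.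

No measurement shown here accounts for either step. On these data alone, it remains open whether piperidin-4-yl on the same chain, a longer chain or an open-chain amine in place of the piperidine would lower the number further, and whether the preference for piperidin-3-yl over piperidin-2-yl holds when the 2-(piperidin-4-yl)ethoxy group is present.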